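The compounds below may be only part of what the source reports. "The series", "measured", "known", "first", "only" and "open" are said of these compounds alone.

Compound 2 `CSc1ccc(S(=O)(=O)NC(=O)Nc2ccc(Cl)cc2)s1` is the starting point. Among the measured compounds shown here, in a functional assay on the whole organism (6C3HED cells, Mus musculus) for inhibition, at a dose of 150 mg/kg by the oral route (a lower number here means less inhibition, a higher number more inhibition at the dose given (going by the name of the read-out)), compound 2 gives 29%, the higher of the two numbers so far, yet within the scatter of compound 1 `Cc1ccc(S(=O)(=O)NC(=O)Nc2ccc(Cl)c(Cl)c2)s1`, which in this assay gives 24%. Compound 3 `CCCOc1ccc(S(=O)(=O)NC(=O)Nc2ccc(Cl)cc2)s1` has not been measured. It differs from compound 2 in a single place: propoxy in place of methylsulfanyl on an aromatic carbon. For the measured compounds named here, no step between measured compounds of this kind is available, so the direction cannot be read off from data, and the expected step of a number 1 percentage points higher from compound 2 to compound 3 (within the scatter) is taken to be none beyond the scatter. Compound 3 is estimated to give 30%, within a range from 12% to 48%.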

Compound 3, a percentage reported as inhibition, in the whole organism at one dose (the size of the read-out at that dose, not a potency): 44%
Compound 3: middle estimate off by 14 percentage points, on the low side; low and high end bracket the measured number.
By their numbers in this assay, from the lowest: compounds 1 and 2 (each within the scatter of the next); then compound 3.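

In this assay, propoxy in place of methylsulfanyl gives a result a number 15 percentage points higher from compound 2 to compound 3 (beyond the scatter). So this position, on an aromatic carbon next to the ring sulfur, does respond to the group it carries, which compounds 1 and 2, differing in more than one place, could not show. Nothing measured here explains the step.

The swap changes chain length and the oxygen-for-sulfur link together, and the compounds shown do not separate the two. Going by these compounds, how a butoxy chain or an amine would fare at this position also remains open.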